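The compounds below may be only part of what the source reports. "The series", "measured", "known", "first", "only" and "open" are said of these compounds alone.

Compound 1 `O=C(CCCCC1CCSS1)NCc1cn(CCCOc2ccc3cc(-c4ccccc4)c(=O)oc3c2)nn1` and compound 2 `COc1ccc(-c2cc3ccc(OCCCn4cc(CNC(=O)CCCCC5CCSS5)nn4)cc3oc2=O)cc1` share a core and differ only in one respect: methoxy in place of hydrogen on an aromatic carbon. In a functional assay on PC-12 cells (Rattus norvegicus) for cytotoxicity, read by MTT assay, with stated times of 3 h and 2 h, tested at 1 uM (on this read-out lower numbers stand for a weaker effect and higher numbers for a stronger effect at the one concentration tested), compound 1 gives 31.9%, while compound 2 gives 47.4%, so that a number 15.5 percentage points higher from compound 1 to compound 2 (beyond the scatter). Compound 3 `O=C(CCCCC1CCSS1)NCc1cn(CCCCOc2ccc3cc(-c4ccccc4)c(=O)oc3c2)nn1` is built on a core that is not the same as that of compound 1; how the two cores differ is not broken down here. In this assay compound 3 gives 34.8%, a number that lies within the scatter of compound 1. Among the compounds with values here, compound 4 `COc1ccc(-c2cc3ccc(OCCCCn4cc(CNC(=O)CCCCC5CCSS5)nn4)cc3oc2=O)cc1` is not yet measured; it differs from compound 3 by methoxy in place of hydrogen on an aromatic carbon, the same change at the same place as the one that separates compound 1 from compound 2. Because that change produced a number 15.5 percentage points higher from compound 1 to compound 2 (beyond the scatter), a step of similar size is expected, namely a number 14.2 percentage points higher from compound 3 to compound 4 (beyond the scatter). Compound 4 is accordingly estimated at 49%, expected to fall between 37% and 61%.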

Compound 4, a percentage reported as activity, at one concentration (the size of the read-out at that concentration, not a potency): 36.8%
For compound 4 the middle estimate is 12.2 percentage points above the measured one; the whole stated range lies above it.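

In this assay, the change from phenyl to 4-methoxyphenyl gave a number 2 percentage points higher from compound 3 to compound 4 (within the scatter), whereas on the other core it gave a number 15.5 percentage points higher from compound 1 to compound 2 (beyond the scatter). Set side by side, the two steps cannot be told apart: the same change on two cores in this assay, a number 15.5 percentage points higher (beyond the scatter) from compound 1 to compound 2 and a number 2 percentage points higher (within the scatter) from compound 3 to compound 4, 13.5 percentage points apart, within the scatter of two such steps. The data therefore do not show that the change behaves differently on the two cores, but with a single pair on each core they do not show that its size carries over either.

The compounds shown leave open whether a hydroxyl or an amine in place of the methoxy, or a longer linking chain, would give a clearer step. On these data alone, how these compounds compare at any other concentration also remains open.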